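Cytotoxicity notes: phenol in place of pyrrolidinylacetamide

The source may hold more compounds than are shown below. What is called first, only, known or untested is meant among the compounds shown, and "the series" means these compounds.

The series shares a benzimidazole-type core carrying a trifluoromethyl group on the fused ring in compounds 1, 2 and 4, and a nitro group there in compound 3. Readout is an ADME assay on MT4 cells (Homo sapiens) for cytotoxicity, read by MTT assay, with a stated time of 96 h; a lower number here means that less compound is tolerated, a higher number that more compound is tolerated.

Compound 1 `Fc1cccc(F)c1-c1nc2cc(C(F)(F)F)ccc2[nH]1` gives 100000 nM in this assay. Compound 2 `O=C(CN1CCCC1)Nc1ccc(-c2nc3cc(C(F)(F)F)ccc3[nH]2)cc1` gives 18000 nM, the lowest of the two numbers shown; its nearest neighbour is compound 1, whose value sits beyond the usual scatter above it. Compound 3 `COc1ccc(-c2nc3cc([N+](=O)[O-])ccc3[nH]2)c(OC)c1` gives only a limit in this assay, > 100000 nM. the limit of > 100000 nM in this assay, at which 1 of the 3 values shown sits, describes where this limit lies.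

Compound 4 `Oc1ccc(-c2nc3cc(C(F)(F)F)ccc3[nH]2)cc1` is not yet measured. It differs from compound 2 as follows: hydroxy in place of (((pyrrolidin-1-yl)methyl)carbonyl)amino on an aromatic carbon. Among the measured compounds shown here, no step between two measured compounds maps directly onto this change, so the expected direction rests on the numbers alone: compound 1 with 100000 nM and compound 2 with 18000 nM mark the span seen so far, and the phenol carries neither the amide nor the saturated ring of compound 2.

The expectation is that compound 4 moves toward the higher, better-tolerated end, with a step of a 3.3-fold higher number from compound 2 to compound 4 (0.52 log units; beyond the scatter) expected. Compound 4 is estimated at 60000 nM, with a likely range from 20000 nM to 150000 nM; a limit-only result is possible.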

Compound 4, half-maximal cytotoxic concentration: 17000 nM
Compound 4: the middle estimate sits 3.5-fold (0.55 log units) above what was measured; measured number below the stated range.
By their numbers in this assay, from the lowest: compounds 4 and 2 (each within the scatter of the next); then compound 1.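

In this assay, hydroxy in place of (((pyrrolidin-1-yl)methyl)carbonyl)amino on an aromatic carbon, para to a large group, gives a 1.1-fold lower number from compound 2 to compound 4 (0.02 log units; within the scatter) and so does not separate the two groups at this position. Compound 2 and compound 4 share this cytotoxicity level even though compound 4 has neither the amide carbonyl nor the five-membered non-aromatic ring, so the number seen for compound 2 does not depend on the presence of that whole side chain. No measured property among the data shown accounts for this match between the two compounds.

Going by these compounds, whether other groups at the same place, such as a primary amine, a carboxylic acid, a methoxy group or a longer chain ending in the same pyrrolidine ring, would stay level with compound 2 and compound 4 remains open. Also open, on these data alone, is whether the same exchange would read alike on a core carrying nitro instead of trifluoromethyl.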